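The source may hold more compounds than are shown below. What is called first, only, known or untested is meant among the compounds shown, and "the series" means these compounds.

Of the compounds shown here, three sharing one core have been tested in a functional assay on HCT-116 cells (Homo sapiens) for inhibition, read by MTT assay, with a stated time of 72 h; a lower number here means a stronger inhibitor, a higher number a weaker inhibitor. Compound 1 `CCOC(=O)c1oc2ccc(NS(=O)(=O)c3ccc(Br)cc3)cc2c1C` gives 9310 nM in this assay, and compound 2 `CCOC(=O)c1oc2ccc(NS(=O)(=O)c3ccc(F)cc3)cc2c1C` gives 10500 nM. The step of a 1.1-fold higher number from compound 1 to compound 2 (0.05 log units; within the scatter) shows that exchanging one halogen for another on the aromatic carbon hardly moves the number. Compound 3 `CCOC(=O)c1oc2ccc(N(Cc3ccccc3)S(=O)(=O)c3ccccc3Br)cc2c1C` carries a benzyl group on the sulfonamide nitrogen. In this assay compound 3 gives only a limit of the assay, > 40000 nM. That reading stands at the limit of > 40000 nM in this assay, at which 1 of the 3 values shown sits. Compound 4 `CCOC(=O)c1oc2ccc(N(Cc3ccccc3)S(=O)(=O)c3cccc(Cl)c3)cc2c1C` has not yet been measured. The change from compound 3 to compound 4 is 3-chlorophenyl in place of 2-bromophenyl on a sulfonyl sulfur. For the measured compounds named here, the only measured step that resembles it, one halogen for another on an aromatic ring, lay within the scatter, so no shift beyond the scatter is expected in this assay, and the benzyl group stays in place. Compound 4 is therefore expected to give about 45000 nM, within 15000 nM to 150000 nM. This estimate means, for compound 4, a step that the limit leaves unreadable from compound 3 to compound 4, with a fair chance that only a limit is reported again.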

Compound 4, half-maximal inhibitory concentration: > 40000 nM
Compound 4 gave a limit, no number; the forecaster's own chance of this, stated with the estimate: 55%; the middle value is on the limit's open side.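

In this assay, for the compounds shown here, compound 3 and compound 4 each give only a limit of the assay, not a number, so no step between them can be read. Still open, from the compounds shown here alone, is whether 3-chlorophenyl in place of 2-bromophenyl on a sulfonyl sulfur changes the inhibition at all.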